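The source may report more compounds than this note shows. Statements on the series, on what has been measured and on what is new or still open speak of the compounds shown alone.

Compounds measured in a functional assay on the whole organism (strain Swiss) with Mus musculus as the target, in the maximal electroshock model, with a stated time of 2 h, at a dose of 300 mg/kg by the intraperitoneal route; a higher number here means a stronger effect of the compound at the dose given, a lower number a weaker effect:
Compound 1 `CCC(C(=O)N1CCN(c2cccc(F)c2)CC1)N1C(=O)CCC1=O`: 0%
Compound 2 `CC(C(=O)N1CCN(c2cccc(F)c2)CC1)N1C(=O)CCC1=O`: 100%
Compound 3 `CCC(C(=O)N1CCN(c2cccc(C(F)(F)F)c2)CC1)N1C(=O)CCC1=O`: 50%

Compound 1 gives the lowest of the three numbers; compound 3 lies nearest to it and compound 2 furthest. Compound 4 `CCC(C(=O)N1CCN(c2ccc(Cl)cc2)CC1)N1C(=O)CCC1=O` differs from compound 1 in one place: 4-chlorophenyl in place of 3-fluorophenyl on an amine nitrogen in a ring. Among the compounds with values here, no measured step repeats this change. The step from compound 1 to compound 3, also a change of the group on the aromatic ring on the same ring nitrogen, was a number 50 percentage points higher from compound 1 to compound 3 (beyond the scatter). The step of a number 100 percentage points higher from compound 1 to compound 2 (beyond the scatter) lies elsewhere in the molecule and bears less on it. A rise beyond the scatter is therefore expected, though smaller than either measured step, since compound 4 keeps the same saturated chain as compound 1 and the aromatic change differs in kind; compound 4 is estimated at 30% (range 0% to 70%), a step of a number 30 percentage points higher from compound 1 to compound 4 (beyond the scatter).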

Compound 4, a percentage reported as activity, at one dose (the size of the read-out at that dose, not a potency): 25%
Estimate against measurement, compound 4: 5 percentage points above; the measured number falls inside the stated range.
By their numbers in this assay, from the lowest: compound 1; then compound 4; then compound 3; then compound 2.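

In this assay, putting 4-chlorophenyl in place of 3-fluorophenyl on the amine nitrogen in the ring gives a number 25 percentage points higher from compound 1 to compound 4 (beyond the scatter) and is a modest step. It is the second change of the aromatic group on this nitrogen to raise the number while the saturated chain stays the same. This change alters both the halogen and its ring position, and the two effects cannot be separated here.

As far as these compounds go, whether 4-chlorophenyl would act the same way with the chain of compound 2, and how a plain phenyl or 4-methoxyphenyl would read, remains open. No evidence is available that accounts for this rise.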